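The source may hold more compounds than are shown below. What is called first, only, known or untested is meant among the compounds shown, and "the series" means these compounds.

Compound 3 `COc1cc(Cl)cc(-c2nn(-c3cccc(NC(=O)Nc4cccc(C(F)(F)F)c4)c3)cc2-c2ccncc2)c1` gives 27% in a functional assay on PC-3 cells (Homo sapiens) for inhibition, read by sulforhodamine B assay, with a stated time of 48 h, tested at 1 uM; on this read-out higher numbers stand for a weaker effect at the one concentration tested and lower numbers for a stronger effect. Among the three measured compounds it stands second highest: compound 1 `COc1cc(Cl)cc(-c2nn(-c3cccc(NC(=O)Nc4ccc(Cl)c(C(F)(F)F)c4)c3)cc2-c2ccncc2)c1` gives 14%, the gap being a number 13 percentage points higher from compound 1 to compound 3 (beyond the scatter), and compound 2 `COc1cc(Cl)cc(-c2nn(-c3cccc(NC(=O)Nc4ccc(Cl)c(Cl)c4)c3)cc2-c2ccncc2)c1` gives 54%, the gap being a number 27 percentage points lower from compound 2 to compound 3 (beyond the scatter). The remaining step, a number 40 percentage points higher from compound 1 to compound 2 (beyond the scatter), is the largest in the set.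

Compound 4 `COc1cc(Cl)cc(-c2nn(-c3cccc(NC(=O)c4cccc(C(F)(F)F)c4)c3)cc2-c2ccncc2)c1` differs from compound 3 by 3-(trifluoromethyl)phenyl in place of (3-(trifluoromethyl)phenyl)amino on a carbonyl carbon. All three measured steps change substituents on the aryl ring attached to the amide-type nitrogen; none touches the carbonyl carbon or removes the amino fragment. Within the data shown here, no measured step therefore bears directly on this change. The measured steps do show that this region of the series moves the read-out by modest to large amounts, so a step beyond the scatter is more likely than not. Without a direct precedent, a weaker effect is expected for compound 4, a number 18 percentage points higher from compound 3 to compound 4 (beyond the scatter), and the estimate is 45% with a range from 15% to 80%.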

Compound 4, a percentage reported as activity, at one concentration (the size of the read-out at that concentration, not a potency): 73%
Compound 4: middle estimate off by 28 percentage points, on the low side; measured number inside the range.
By their numbers in this assay, from the lowest: compound 1; then compound 3; then compound 2; then compound 4.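

Within this assay, the amino fragment on the carbonyl carbon emerges as a second sensitive point in the series, beyond the aryl substituents: replacing (3-(trifluoromethyl)phenyl)amino with 3-(trifluoromethyl)phenyl weakens the effect (a number 46 percentage points higher from compound 3 to compound 4 (beyond the scatter)). The loss also holds against the other two amino-bearing compounds (a number 19 percentage points higher from compound 2 to compound 4 (beyond the scatter); a number 59 percentage points higher from compound 1 to compound 4 (beyond the scatter)), so among the four compounds shown, none with the amino fragment is as weak as compound 4, and none goes against this pattern. Nothing shown explains the loss.

Since the change removes both the nitrogen and the amide hydrogen, the data cannot separate the role of either from the shortened link. A methylene or an oxygen in place of the amino nitrogen, or a methylamino group, would bear on this, as would the same change on a 3,4-dichlorophenyl partner.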